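The source may report more compounds than this note shows. Statements on the series, on what has been measured and on what is new or still open speak of the compounds shown alone.

In a functional assay on HeLa cells (Homo sapiens) for inhibition, read by CCK-8 assay, with a stated time of 72 h, tested at 2 uM (on this read-out lower numbers stand for less inhibition of growth and higher numbers for more inhibition of growth at the one concentration tested), compound 1 `Cc1ccc(SCc2ccc(C(=O)Nc3ccccc3N)cc2)cc1` gives 33.8%. Compound 3 `COC(=O)c1ccccc1SCc1ccc(C(=O)Nc2ccccc2N)cc1` gives 29.8%, a number within the scatter of that of compound 1. Compound 2 `Nc1ccccc1NC(=O)c1ccc(CSc2ccc(C(F)(F)F)cn2)cc1` gives 11.5%, lower than compound 1 by more than the scatter. Compound 4 `Nc1ccccc1NC(=O)c1ccc(CSc2ccc(F)cc2)cc1` differs from compound 1 by fluoro in place of methyl on an aromatic carbon, para to a large group. Going by the values given here, no two measured compounds differ in one place, so the data offer no direct guide to this change, and no step beyond the scatter is expected in this assay. The estimated step is a number 3.8 percentage points lower from compound 1 to compound 4 (within the scatter), expected to stay within the scatter. For compound 4 the estimated value is 30%, with an expected range of 15% to 45%.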

Compound 4, percent growth inhibition at one concentration: 27.9%
The estimate for compound 4 lay 2.1 percentage points above the measured number; low and high end bracket the measured number.
By their numbers in this assay, from the lowest: compound 2; then compounds 4, 3 and 1 (each within the scatter of the next).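

In this assay, going by these compounds alone, fluoro in place of methyl on an aromatic carbon, para to a large group, gives a number 5.9 percentage points lower from compound 1 to compound 4 (within the scatter), the only step here between compounds that differ in one place. At this position, therefore, the 4-methylphenyl and 4-fluorophenyl groups cannot be told apart on this read-out. Nothing at hand explains this result.

From the compounds shown here alone, whether an amine, a carboxylic acid or a longer chain at this position would move the number beyond the scatter remains open. So does whether fluoro elsewhere on this ring would leave it unchanged.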